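This account rests on a few compounds, and the source may have more. Where it says the series, first, only, none or still open, it means among the compounds named here.

Of the compounds shown here, two built on the same core have been measured in an assay on isolated protein for inhibition of Rho-associated protein kinase 2 (Homo sapiens), read by scintillation counting, radiometric assay and 33P incorporation, with a stated time of 40 min, in the presence of a further agent that is not named here; on this read-out higher numbers stand for weaker inhibition and lower numbers for stronger inhibition. Compound 1 `Cc1coc2cc(OCC(=O)Nc3cccc(NC(=O)c4ccc(N(C)C)cc4)c3)ccc2c1=O` carries an amide link to a 4-(dimethylamino)phenyl group, and in this assay compound 1 gives 2150 nM. Compound 2 `CN(C)c1ccc(S(=O)(=O)Nc2cccc(NC(=O)COc3ccc4c(=O)ccoc4c3)c2)cc1` carries the same 4-(dimethylamino)phenyl group through a sulfonamide instead, and in this assay compound 2 gives 263 nM. Of the two numbers compound 2 holds the lower one, and the gap to compound 1 lies beyond the usual scatter.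

Compound 3 `O=C(COc1ccc2c(=O)ccoc2c1)Nc1cccc(NS(=O)(=O)c2ccc(OC(F)(F)F)cc2)c1` keeps the sulfonamide of compound 2 and differs from it in one place: trifluoromethoxy in place of dimethylamino on an aromatic carbon. Among the compounds with values here, no measured pair shows this exchange on this core, so there is nothing in the data to say how large a step it brings or in which direction. Compound 3 is therefore expected to land near compound 2, with a step of a 1.5-fold higher number from compound 2 to compound 3 (0.18 log units; within the scatter) in this assay that may well stay within the scatter. The estimate for compound 3 in this assay is 400 nM, with a range from 100 nM to 2000 nM.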

Compound 3, half-maximal inhibitory concentration: 1280 nM
For compound 3 the middle estimate is 3.2-fold (0.51 log units) below the measured one; measured number inside the range.
By their numbers in this assay, from the lowest: compound 2; then compounds 3 and 1 (each within the scatter of the next).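

Within the data shown here, the exchange of dimethylamino for trifluoromethoxy gives the first measured step at this position on the shared core: in this assay it is a 4.9-fold higher number from compound 2 to compound 3 (0.69 log units; beyond the scatter). This shows that, with the sulfonamide held constant, the group on this aromatic carbon affects the read-out, and that of these two groups dimethylamino goes with the stronger inhibition. The exchange replaces 3 heavy atoms with 5 while the counts of hydrogen-bond donors and acceptors stay equal, so those counts do not separate the two compounds, and no measurement here accounts for the size or direction of the step.

Among these compounds, with only two groups compared at this position on the sulfonamide series, it remains open how a plain hydrogen, a methoxy group or an amine with longer chains on its nitrogen would compare with dimethylamino. Going by these compounds, it also remains open whether the same exchange would bring a step of similar size on the amide-linked compound 1, whose core differs from that of compound 2 in more than one place.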